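Swapping Butyl for Phenyl at a Chain Carbon

This account rests on a few compounds, and the source may have more. Where it says the series, first, only, none or still open, it means among the compounds named here.

Measured compounds in an assay on isolated protein for inhibition of Polyunsaturated fatty acid lipoxygenase ALOX15 (Homo sapiens), read by spectrophotometry, with a stated time of 10 min; on this read-out higher numbers stand for weaker inhibition and lower numbers for stronger inhibition:
compound 1, `CCCCNC(=O)c1cc(C)sc1N`, gives >= 50000 nM
compound 2, `CCCCNC(=O)c1cc(CC)sc1N`, gives >= 50000 nM
compound 3, `CCCCCc1cc(C(=O)NCCCC)c(N)s1`, gives >= 50000 nM

Compound 3 stands at a limit of this assay rather than at a measured number. Compound 1 likewise stands at a limit. Compound 2 also stands at a limit. Going by the values given here, as the limit of >= 50000 nM in this assay, at which 3 of the 3 values shown sit, shows, every value so far is such a limit, so the steps a step that the two limits leave unreadable from compound 1 to compound 2, a step that the two limits leave unreadable from compound 1 to compound 3 and a step that the two limits leave unreadable from compound 2 to compound 3 cannot be read in size or direction: each adds a saturated chain to the shared core, and none of them lifts inhibition into the range where this assay returns a number.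

Compound 4, `CCCCNC(=O)c1cc(Cc2ccccc2)sc1N`, changes the same position once more: phenyl in place of butyl on a saturated chain carbon bound to an aromatic carbon. Among the compounds with values here, the steps that bear on this place, from compound 1 onward, are all unreadable, so no trend can be taken from them; the only thing known is that chains of three different lengths at this carbon all stayed at the limit. The expectation is therefore that compound 4 most likely remains at or near the limit as well, with the step of a number no higher from compound 3 to compound 4 (the limit leaves the size open) expected to be no more than scatter. Compound 4 is estimated at 50000 nM in this assay, within 15000 nM to 100000 nM.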

Compound 4, half-maximal inhibitory concentration: >= 50000 nM
Compound 4: a limit, no number; the forecaster's own chance of this, stated with the estimate: 70%; the middle value lies on the limit itself.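

Compound 4 also stands at a limit rather than at a number, so its steps from compound 1, compound 2 and compound 3 cannot be read in size or direction: the limit of >= 50000 nM in this assay, at which 4 of the 4 values shown sit. The compounds shown leave open which change at this chain carbon, if any, would bring inhibition in this assay into the range where a number is returned.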